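Removing the alpha cap from a hydroxamate pair

This account rests on a few compounds, and the source may have more. Where it says the series, first, only, none or still open, it means among the compounds named here.

Two hydroxamates have been run in an assay on isolated protein for inhibition of protein deacetylase HDAC6 (Homo sapiens), read by fluorescence; a higher number here means a weaker inhibitor, a lower number a stronger inhibitor. Compound 1 `O=C(CCCCC[C@H](NC(=O)[C@@H]1CCCC(=O)N1)C(=O)Nc1ccccc1)NO` gives 5 nM in this assay. Compound 2 `Cc1ccc(NC(=O)[C@H](CCCCCC(=O)NO)NC(=O)[C@H]2CCC(=O)N2)cc1` gives 4 nM in this assay, the lower of the two numbers, with compound 1 as its nearest neighbour and within the scatter of it, so the two cannot be ranked on these data.

Compound 3 `Cc1ccc(NC(=O)CCCCCCC(=O)NO)cc1` differs from compound 2 in one place: hydrogen in place of ((5-oxopyrrolidin-2-yl)carbonyl)amino on a saturated chain carbon bound to a carbonyl carbon and a saturated chain carbon. For the measured compounds named here, no step between measured compounds matches this change, so there is no measured step to set its size. Dropping a group of that size, with its donors, acceptors and stereocentre, is expected to weaken inhibition rather than leave it unchanged, and the step is estimated at a 5.0-fold higher number from compound 2 to compound 3 (0.70 log units; beyond the scatter), a moderate loss beyond the scatter. Compound 3 is therefore expected to give about 20 nM in this assay, with a range from 6 nM to 70 nM.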

Compound 3, half-maximal inhibitory concentration: 12 nM
The estimate for compound 3 lay 1.7-fold (0.22 log units) above the measured number; the range from low to high includes it.
By their numbers in this assay, from the lowest: compounds 2 and 1 (each within the scatter of the next); then compound 3.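

Hydrogen in place of ((5-oxopyrrolidin-2-yl)carbonyl)amino on this saturated chain carbon gives a 3.0-fold higher number from compound 2 to compound 3 (0.48 log units; beyond the scatter) in this assay, the first measured step at this position. The step is modest for a change that removes 9 heavy atoms, a five-membered non-aromatic ring and 1 defined stereocentre, and compound 3 still gives 12 nM without the group, so the group is not required for inhibition in the nanomolar range. Nothing available explains the size of this step.

As far as these compounds go, it remains open how much of the step belongs to the ring and how much to the amide, which a simple acetylamino group on the same carbon would help to separate. Also open, from the compounds shown here alone, is whether an amine or a carboxylic acid at this position would match compound 2 or fall to the level of compound 3.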